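Thiophene exchange on the core of compound 1

This account rests on a few compounds, and the source may have more. Where it says the series, first, only, none or still open, it means among the compounds named here.

In a functional assay on cells (Cancer cell lines, Homo sapiens) for inhibition (on this read-out lower numbers stand for stronger inhibition of growth and higher numbers for weaker inhibition of growth), compound 1 `N=C(N)N/N=C/c1c(-c2cc(Cl)sc2Cl)nc2n1CCS2` gives 15100 nM as its measured number. For the measured compounds named here, compound 2 `N=C(N)N/N=C/c1c(-c2cccs2)nc2sccn12`, the one measured compound bearing thiophen-2-yl, gives 24500 nM and lies within the scatter of compound 1, so these two numbers do not set compound 1 apart.

Compound 3 `N=C(N)N/N=C/c1c(-c2cccs2)nc2n1CCS2` keeps the core of compound 1, with thiophen-2-yl in place of 2,5-dichlorothiophen-3-yl on an aromatic carbon. Going by the values given here, no measured pair isolates this exchange, so the evidence for its size is thin. Among the compounds with values here, no step clearly beyond the scatter is expected, only a possible drift toward a higher number, and the estimated step is (a 1.6-fold higher number from compound 1 to compound 3 (0.20 log units; within the scatter)) at that scale. Within the data shown here, the lean in that direction rests on compound 2 at (24500 nM) as the only measured number for a compound with thiophen-2-yl. The estimated value for compound 3 is 24000 nM with an expected range of 11000 nM to 50000 nM in this read-out.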

Compound 3, concentration for total growth inhibition: 36300 nM
Compound 3: the middle estimate sits 1.5-fold (0.18 log units) below what was measured, within the range that was stated.
By their numbers in this assay, from the lowest: compounds 1, 2 and 3 (each within the scatter of the next, the first and the last beyond it).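

In this assay, for the compounds shown here, thiophen-2-yl in place of 2,5-dichlorothiophen-3-yl on the core of compound 1 gives a 2.4-fold higher number from compound 1 to compound 3 (0.38 log units; beyond the scatter) and provides the first measured pair that isolates this exchange. Going by these compounds alone, the step is modest, but it shows that the number responds to the group on this aromatic carbon of the five-membered aromatic ring with 2 nitrogen, which the earlier compounds could not show because they differ in more than one place. The exchange alters both the chlorine substitution and the point of attachment of the thiophene, and no supporting measurement is available to separate these two differences or explain the step.

The compounds shown leave open whether a monochlorinated thiophene, a 2,5-dichlorothiophen-2-yl-type arrangement being impossible, or a thiophen-3-yl group without chlorine would account for the step. They also leave open how this aromatic carbon would respond to a group outside the thiophene family, such as phenyl, an amine or a carboxylic acid, and whether a longer chain there would move the number in either direction.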